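Swapping 3-methoxyphenyl for 4-methylphenyl in a narrow series

The source may report more compounds than this note shows. Statements on the series, on what has been measured and on what is new or still open speak of the compounds shown alone.

Of the compounds shown here, three with a shared core have been measured in a functional assay on HL-60 cells (Homo sapiens) for cytotoxicity, read by WST assay, with a stated time of 48 h; a higher number here means that more compound is needed for the effect, a lower number that less compound is needed. Compound 1 `O=C1OC[C@H](Cc2ccccc2F)[C@H]1Cc1ccc(Cl)c(Cl)c1` gives 28000 nM, compound 2 `O=C1OC[C@H](Cc2cccc(O)c2)[C@H]1Cc1ccc(Cl)c(Cl)c1` gives 48000 nM, and compound 3 `COc1cccc(C[C@H]2COC(=O)[C@@H]2Cc2ccc(Cl)c(Cl)c2)c1` gives 34000 nM. Compound 3 thus stands within the scatter of both others, so the three values cannot be ranked.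

Compound 4 `Cc1ccc(C[C@H]2COC(=O)[C@@H]2Cc2ccc(Cl)c(Cl)c2)cc1` has not yet been measured. It carries 4-methylphenyl in place of 3-methoxyphenyl on a saturated chain carbon bound to a saturated ring carbon.

Among the compounds with values here, no measured step involves 4-methylphenyl, so the evidence is indirect. At the same place, replacing 2-fluorophenyl gave a 1.7-fold higher number from compound 1 to compound 2 (0.23 log units; within the scatter) and a 1.2-fold higher number from compound 1 to compound 3 (0.08 log units; within the scatter). Methyl in place of hydrogen on the oxygen on the aromatic ring gave a 1.4-fold lower number from compound 2 to compound 3 (0.15 log units; within the scatter). All three steps stay within the scatter, so no step beyond the scatter is expected in this assay, and no direction can be favoured. The estimated outcome is a 1.1-fold higher number from compound 3 to compound 4 (0.02 log units; within the scatter). For compound 4 the estimated value is 36000 nM, with an expected range from 18000 nM to 70000 nM.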

Compound 4, half-maximal effective concentration: 19000 nM
Compound 4: middle estimate off by 1.9-fold (0.28 log units), on the high side; the measured number falls inside the stated range.
By their numbers in this assay, from the lowest: compounds 4, 1, 3 and 2 (each within the scatter of the next, the first and the last beyond it).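

In this assay the place on a saturated chain carbon bound to a saturated ring carbon now gives its first step beyond the scatter, a 2.5-fold lower number from compound 2 to compound 4 (0.40 log units; beyond the scatter) with 4-methylphenyl in place of 3-hydroxyphenyl, so the group held here can move the number, though only modestly. Against the other two groups the change stays within the scatter, with a 1.8-fold lower number from compound 3 to compound 4 (0.25 log units; within the scatter) for 4-methylphenyl in place of 3-methoxyphenyl and a 1.5-fold lower number from compound 1 to compound 4 (0.17 log units; within the scatter) for 4-methylphenyl in place of 2-fluorophenyl, so compound 4 separates from compound 2 alone, and the swap for 3-methoxyphenyl cannot be read as a real change. No measurement at hand offers an explanation for the separation from compound 2.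

The compounds shown leave open whether the gap between compound 2 and compound 4 follows from the methyl group itself or from where it sits on the ring, a question that 3-methylphenyl or 4-hydroxyphenyl at this place would address. They also leave open whether an amine or a carboxylic acid on this ring, or a longer chain in place of the single carbon link, would move the number further than any group seen so far.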